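From chloro to hydrogen at the limit of the assay

The source may report more compounds than this note shows. Statements on the series, on what has been measured and on what is new or still open speak of the compounds shown alone.

Measured compounds:
compound 1 `COc1cc(-c2ncnn2-c2ccc([N+](=O)[O-])cc2)cc(OC)c1OC` gives > 10000 nM (a limit)
compound 2 `COc1cc(-c2ncnn2-c2ccc(Cl)cc2)cc(OC)c1OC` gives > 10000 nM (a limit)

In a functional assay on Jurkat cells (Homo sapiens) for antiproliferative activity, read by MTT assay, with a stated time of 72 h (on this read-out higher numbers stand for weaker inhibition and lower numbers for stronger inhibition), compound 2 gives > 10000 nM, which is a limit and not a number. Compound 1 gives > 10000 nM, which is likewise a limit. No measured number is therefore available to place compound 2 against.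

Compound 3 `COc1cc(-c2ncnn2-c2ccccc2)cc(OC)c1OC` differs from compound 2 by one change, (hydrogen in place of chloro on an aromatic carbon), that is, hydrogen in place of chloro on an aromatic carbon, para to a large group. Among the measured compounds shown here, the one measured step that bears on it is a step that the two limits leave unreadable from compound 1 to compound 2, chloro in place of nitro on an aromatic carbon. It has no readable size, and the evidence amounts to the limit of > 10000 nM in this assay, at which 2 of the 2 values shown sit. No sized step in either direction can be drawn from this, so none beyond the scatter is expected in this assay. The estimated step is a step that the limit leaves unreadable from compound 2 to compound 3, and a report as a limit is the likeliest outcome. Compound 3 is expected at about 15000 nM (5000 nM to 50000 nM) on this estimate.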

Compound 3, half-maximal inhibitory concentration: > 10000 nM
Compound 3: a limit, no number; the forecaster's own chance of this, stated with the estimate: 85%; the middle value is on the limit's open side.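

In this assay compound 3 gives > 10000 nM, which is a limit and not a number. Among the compounds shown here, no step among compound 1, compound 2 and compound 3 can be read: the limit of > 10000 nM in this assay, at which 3 of the 3 values shown sit. The compounds shown leave open how far each lies past that limit, and whether nitro, chloro or hydrogen at that place makes any difference in this assay.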